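A few compounds are considered here, and "the series" means these few. Any claim that something is new, unique, unknown or untested is made for them only; others in the source may bear on it.

Of the compounds shown here, two have been measured so far. Compound 1 `CCCCn1c(-c2ccc(OC)cc2)cnc1NC(=O)c1ccc(F)cc1` and compound 2 `COc1ccc(-c2cnc(NC(=O)c3cccc(OC)c3)n2C)cc1` were both tested in a toxicity assay on THP-1 cells (Homo sapiens) for inhibition; a higher number here means that more compound is tolerated, a lower number that less compound is tolerated. In this assay compound 1 gives > 100000 nM, which is a limit of the assay rather than a number. Compound 2 likewise gives > 100000 nM in this assay, again a limit rather than a measured value. Compound 2 thus stands at the limit of > 100000 nM in this assay, at which 2 of the 2 values shown sit, and the two values show no difference between them. Compound 3 `COc1ccc(-c2cnc(NC(=O)c3ccccc3C#N)n2C)cc1` has not yet been measured in this assay; it differs from compound 2 by 2-cyanophenyl in place of 3-methoxyphenyl on a carbonyl carbon. Going by the values given here, no step between measured compounds is known here, so the expectation for compound 3 rests on the two limits alone. Compound 3 is therefore expected to stay at the same limit. The step of a number no higher from compound 2 to compound 3 (the limit leaves the size open) is expected to be none beyond the scatter. For compound 3 the estimate is 100000 nM, within a range from 50000 nM to 200000 nM, most likely reported once more only as a limit.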

Compound 3, half-maximal cytotoxic concentration: > 100000 nM
Compound 3: only a limit was reported; the forecaster's own chance of this, stated with the estimate: 85%; the middle value lies on the limit itself.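

Going by these compounds alone, compound 3, like compound 2, sits at a limit in this assay, and no step between compound 2 and compound 3 can be read. The compounds shown leave open whether 2-cyanophenyl and 3-methoxyphenyl differ at all in this assay, and how much of any compound is tolerated: the limit of > 100000 nM in this assay, at which 3 of the 3 values shown sit.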